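The source may report more compounds than this note shows. Statements on the series, on what has been measured and on what is new or still open speak of the compounds shown alone.

In an assay with sodium channel protein type 3 subunit alpha (Homo sapiens) as the target, read by patch clamp (on this read-out lower numbers stand for stronger inhibition and higher numbers for weaker inhibition), compound 1 `Nc1nc2c(s1)CC(CNC(=O)c1cc3ccccc3[nH]1)CC2` gives 16000 nM. Compound 2 `Nc1nc2c(s1)C[C@@H](NC(=O)c1ccc[nH]1)CC2` reaches only a limit of the assay, > 30000 nM. Of the two values shown, compound 2 is the one that sits at the limit of > 30000 nM in this assay, at which 1 of the 2 values shown sits. Compound 3 `Cn1cccc1C(=O)N[C@H]1CCc2nc(N)sc2C1` differs from compound 2 by methyl in place of hydrogen on an aromatic nitrogen. Going by the values given here, no measured step shows what this change does in this assay, so the expected step of a number no higher from compound 2 to compound 3 (the limit leaves the size open) is none beyond the usual scatter, in either direction. Compound 3 is therefore expected to give about 30000 nM, in the range 10000 nM to 100000 nM.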

Compound 3, half-maximal inhibitory concentration: 24000 nM
Compound 3: the middle estimate sits 1.3-fold (0.10 log units) above what was measured; measured number inside the range.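

In this assay, the step for methyl in place of hydrogen on an aromatic nitrogen is an at least 1.2-fold lower number from compound 2 to compound 3 (0.09 log units; that floor lies within the scatter) and so does not yet show a change beyond the scatter. Compound 3 gives 24000 nM as a true number, so the 1-methyl-1H-pyrrol-2-yl group brings this series onto the readable scale. The step remains only a floor because compound 2 stands at a limit of the assay: the limit of > 30000 nM in this assay, at which 1 of the 3 values shown sits.

Going by these compounds, the true size of the step stays open. So does whether ethyl or a longer chain on this nitrogen would move the number further.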